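The compounds below may be only part of what the source reports. "The series", "measured", "known", "first", "only" and "open" are said of these compounds alone.

Compounds measured in a functional assay on HT-29 cells (Homo sapiens) for cytotoxicity, read by MTT assay, with a stated time of 72 h; a lower number here means a stronger inhibitor, a higher number a weaker inhibitor:

Compound 1, `CN(C)CCn1cnnc1-c1cc(Oc2ccc(NC(=O)N/N=C/c3ccc(Cl)cc3)cc2F)ccn1`, gives 530 nM.
Compound 2, `CN(C)CCn1cnnc1-c1cc(Oc2ccc(NC(=O)N/N=C/c3ccc(O)c(F)c3)cc2F)ccn1`, gives 3310 nM.
Compound 3, `CN(C)CCn1cnnc1-c1cc(Oc2ccc(NC(=O)N/N=C/c3ccc(O)c(Br)c3)cc2F)ccn1`, gives 450 nM.

Compound 1 stands second highest of the three numbers; compound 3 sits a 1.2-fold lower number from compound 1 to compound 3 (0.07 log units; within the scatter), and compound 2 sits a 6.2-fold higher number from compound 1 to compound 2 (0.80 log units; beyond the scatter). The step of a 7.4-fold lower number from compound 2 to compound 3 (0.87 log units; beyond the scatter) is the one clear swing in the set, and it comes from one halogen replacing another on the aromatic ring at the carbon with a double bond to nitrogen.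

Compound 4, `CN(C)CCn1cnnc1-c1cc(Oc2ccc(NC(=O)N/N=C/c3ccccc3)cc2F)ccn1`, differs from compound 1 by hydrogen in place of chloro on an aromatic carbon. Going by the values given here, no measured step removes a halogen from that ring outright, so the bearing of the earlier steps is indirect. From compound 1 to compound 3 the chloro gives way to a bromo plus hydroxyl with little movement in the number, while from compound 2 to compound 3 the heavier halogen brings the stronger inhibition. Both point to the halogen on that ring carrying weight, so losing it is expected to move compound 4 toward a somewhat higher number in this assay, though not necessarily beyond the scatter. The expected step is a 1.9-fold higher number from compound 1 to compound 4 (0.28 log units; within the scatter). Compound 4 is estimated at 1000 nM, with a range from 400 nM to 2500 nM.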

Compound 4, half-maximal inhibitory concentration: 1120 nM
For compound 4 the middle estimate is 1.1-fold (0.05 log units) below the measured one, and the stated range covers the measured number.
By their numbers in this assay, from the lowest: compounds 3 and 1 (each within the scatter of the next); then compound 4; then compound 2.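

In this assay, going by these compounds alone, the change from 4-chlorophenyl to phenyl gives a 2.1-fold higher number from compound 1 to compound 4 (0.32 log units; beyond the scatter) and provides the first direct reading of the chloro at this position, on an aromatic carbon para to a large group, against plain hydrogen. Phenyl in place of 3-bromo-4-hydroxyphenyl gives a 2.5-fold higher number from compound 3 to compound 4 (0.40 log units; beyond the scatter) while phenyl in place of 3-fluoro-4-hydroxyphenyl gives a 3.0-fold lower number from compound 2 to compound 4 (0.47 log units; beyond the scatter) so the unsubstituted ring now serves as a reference that lies between the substituted rings. Substitution on this ring therefore does not move the number in one direction: compound 1 and compound 3 lie lower than compound 4, but compound 2 goes against that pattern despite also carrying a halogen.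

No measurement available here accounts for these steps.
Open, on these data alone, is what the hydroxyl and the halogen each contribute on their own, and how a methoxy group or an amine in place of the chloro would compare with compound 1 and compound 4.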